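The source may hold more compounds than are shown below. What is called first, only, known or untested is meant among the compounds shown, and "the series" means these compounds.

Measured so far in a functional assay on SMMC-7721 cells (Homo sapiens) for antiproliferative activity, read by MTT assay, with a stated time of 72 h; on this read-out higher numbers stand for weaker inhibition and lower numbers for stronger inhibition:
compound 1, `Cc1nn(C)c(Oc2ccc(F)cc2)c1/C=N\OCc1c(Cl)c(-c2ccc(Cl)cc2)nn1C`: 3230 nM
compound 2, `Cc1nn(C)c(Oc2ccc(Cl)cc2)c1/C=N\OCc1c(Cl)c(-c2ccc(Cl)cc2)nn1C`: 6820 nM

Among the compounds with values here, compound 2 stands at the higher of the two numbers in this assay; the single step, a 2.1-fold higher number from compound 1 to compound 2 (0.32 log units; beyond the scatter), separates them. Compound 3, `Cc1nn(C)c(Oc2ccc(Br)cc2)c1/C=N\OCc1c(Cl)c(-c2ccc(Cl)cc2)nn1C`, differs from compound 2 by bromo in place of chloro on an aromatic carbon. Within the data shown here, only that one step bears on this change, and it was modest, so a step of similar or smaller size is expected here, more likely upward than downward, though it may stay within the scatter. Compound 3 is estimated at 8500 nM, between 3500 nM and 20000 nM; the expected step is a 1.2-fold higher number from compound 2 to compound 3 (0.10 log units; within the scatter).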

Compound 3, half-maximal inhibitory concentration: 7130 nM
Beside the measured number, compound 3's estimate is 1.2-fold (0.08 log units) above it; low and high end bracket the measured number.
By their numbers in this assay, from the lowest: compound 1; then compounds 2 and 3 (each within the scatter of the next).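

In this assay, chloro and bromo at this place on the phenoxy ring cannot be told apart: a 1.0-fold higher number from compound 2 to compound 3 (0.02 log units; within the scatter) stays within the scatter. Fluoro remains the one separated, since a 2.2-fold higher number from compound 1 to compound 3 (0.34 log units; beyond the scatter) lies beyond the scatter, as does the earlier chloro step, so bromo adds a second compound on the same side of that gap. No measurement at hand accounts for this split.

Open, as far as these compounds go, is whether an amine, a methoxy group or a carboxylic acid at this place would move the number beyond the scatter. Also open, from the compounds shown here alone, is whether the same halogen swaps on the 4-chlorophenyl group would behave alike.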